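The compounds below may be only part of what the source reports. "The series", "measured", "known", "first", "only" and "open" are said of these compounds alone.

Working notes on the series.

Two members of the series carry a measurement in an ADME assay on HepG2 cells (Homo sapiens) for cytotoxicity, read by MTT assay, with a stated time of 48 h; on this read-out lower numbers stand for higher toxicity in this test and higher numbers for lower toxicity in this test. Compound 1 `CC(=O)OC[C@H]1O[C@H](OC[C@H](Cn2cc(COc3ccc(-c4noc(C)n4)cc3)nn2)OC(C)=O)C=C[C@@H]1OC(C)=O` gives 37.7 ug/mL in this assay. Compound 2 `CC(=O)OC[C@H]1O[C@H](OC[C@@H](Cn2cc(CN(c3nc(-c4ccc(Cl)cc4)no3)C3CCCCC3)nn2)OC(C)=O)C=C[C@@H]1OC(C)=O` gives 46.9 ug/mL in this assay, the higher of the two numbers; the gap to compound 1 lies within the scatter, so the two numbers show no difference that can be read as an order.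

The next member is compound 3 `CC(=O)OC[C@H]1O[C@H](OC[C@@H](Cn2cc(CN(c3nc(-c4cccc(C)c4)no3)C3CCCCC3)nn2)OC(C)=O)C=C[C@@H]1OC(C)=O`, not yet measured in this assay. It differs from compound 2 by 3-methylphenyl in place of 4-chlorophenyl on an aromatic carbon. For the measured compounds named here, no measured pair reports a step of this kind, so the expectation rests only on compound 2 and its value 46.9 ug/mL. No step beyond the scatter is expected in this assay, in either direction; the estimated step is a 1.0-fold lower number from compound 2 to compound 3 (0.02 log units; within the scatter). Compound 3 is therefore expected to give about 45 ug/mL in this assay, with a range from 25 ug/mL to 80 ug/mL.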

Compound 3, half-maximal cytotoxic concentration: 39.2 ug/mL
Compound 3: the middle estimate sits 1.1-fold (0.06 log units) above what was measured; measured number inside the range.
By their numbers in this assay, from the lowest: compounds 1, 3 and 2 (each within the scatter of the next).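

In this assay, for the compounds shown here, 3-methylphenyl in place of 4-chlorophenyl on the aromatic carbon of the five-membered aromatic ring gives a 1.2-fold lower number from compound 2 to compound 3 (0.08 log units; within the scatter), the first step that can be read at this position. Here, the two aryl groups, each of 7 heavy atoms, show no difference that can be read as an order, even though chlorine is exchanged for carbon and the name of the substituted ring position changes with it. No measurement on hand bears on the reason for this result.

The compounds shown leave open whether an amine or a carboxylic acid on this phenyl ring would give a step beyond the scatter. They also leave open how 3-chlorophenyl and 4-methylphenyl would read at the same place, so the chlorine-to-methyl exchange cannot be separated from the shift in ring position.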